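Methoxycarbonyl in place of thiophen-2-yl on a carbonyl carbon

The source may hold more compounds than are shown below. What is called first, only, known or untested is meant among the compounds shown, and "the series" means these compounds.

Measured in a functional assay on SiHa cells (Homo sapiens) for inhibition (on this read-out lower numbers stand for stronger inhibition and higher numbers for weaker inhibition), so far:
- compound 1 `COc1cc(/C=C/C(=O)c2cccc(NC(=O)c3cccs3)c2)ccc1O` gives 6.57 ug/mL
- compound 2 `COc1cc(/C=C/C(=O)c2cccc(N)c2)ccc1O` gives 12.3 ug/mL
- compound 3 `COc1cc(/C=C/C(=O)c2cccc(NC(=O)C(C)C)c2)ccc1O` gives 5.96 ug/mL

In this assay compound 1 cannot be separated from either of the other two compounds, since both of its steps stay within the scatter. Going by the values given here, only the step between the other two goes beyond it, and then only modestly (a 2.1-fold lower number from compound 2 to compound 3 (0.31 log units; beyond the scatter)).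

Compound 4 `COC(=O)C(=O)Nc1cccc(C(=O)/C=C/c2ccc(O)c(OC)c2)c1` has not yet been measured. It keeps the core of compound 1 and differs in a single group (methoxycarbonyl in place of thiophen-2-yl on a carbonyl carbon).

One measured step changes the group at this same place (a 1.1-fold lower number from compound 1 to compound 3 (0.04 log units; within the scatter)), and it stays within the scatter. Removing the whole acyl group from compound 1 also gives a step within the scatter (a 1.9-fold higher number from compound 1 to compound 2 (0.27 log units; within the scatter)), but compound 4 keeps its carbonyl on the nitrogen, so that step bears on it less directly. Among the compounds with values here, no measured compound carries methoxycarbonyl, so the evidence for this group is indirect and the range stays wide.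

No step beyond the scatter is therefore expected (a 1.1-fold higher number from compound 1 to compound 4 (0.03 log units; within the scatter)). For compound 4 the estimate is 7 ug/mL, with an expected range from 3.5 ug/mL to 14 ug/mL.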

Compound 4, half-maximal inhibitory concentration: 7.71 ug/mL
Estimate against measurement, compound 4: 1.1-fold (0.04 log units) below; low and high end bracket the measured number.
By their numbers in this assay, from the lowest: compounds 3, 1, 4 and 2 (each within the scatter of the next, the first and the last beyond it).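

In this assay, the thiophen-2-yl group on the carbonyl carbon can give way to methoxycarbonyl, which has no ring and adds a second carbonyl to the acyl chain, without a step beyond the scatter (a 1.2-fold higher number from compound 1 to compound 4 (0.07 log units; within the scatter)), and methoxycarbonyl also cannot be separated from isopropyl at this place (a 1.3-fold higher number from compound 3 to compound 4 (0.11 log units; within the scatter)). Thiophen-2-yl, isopropyl and methoxycarbonyl therefore make three different groups on this carbonyl carbon that cannot be told apart, while the amine of compound 2 is separated from compound 3 (a 2.1-fold lower number from compound 2 to compound 3 (0.31 log units; beyond the scatter)) but not from compound 4 (a 1.6-fold lower number from compound 2 to compound 4 (0.20 log units; within the scatter)), so acylating that nitrogen does not give a step beyond the scatter in every case. No measurement shown here offers an explanation for this result.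

The compounds shown leave open whether a carboxylic acid, a primary amine or a longer alkyl chain on this carbonyl carbon would also stay within the scatter of compound 1. They also leave open whether any group at this place, such as a substituted phenyl ring, can produce a step beyond the scatter from compound 1 at all.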